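The compounds below may be only part of what the source reports. "The series", "measured", "known", "first", "only" and "open" are said of these compounds alone.

For the measured compounds named here, of the two compounds measured so far, compound 2 `CC(C(=O)NCc1ccc(C(F)(F)F)nc1-c1ccc(F)c(Cl)c1)c1ccc(NS(C)(=O)=O)c(F)c1` shows the lower number: in an assay on CHO cells for antagonist activity at transient receptor potential cation channel subfamily V member 1 (Homo sapiens), read by FLIPR (on this read-out higher numbers stand for weaker inhibition and lower numbers for stronger inhibition), compound 2 gives 0.2 nM, while compound 1 `CC(C(=O)NCc1ccc(C(F)(F)F)nc1-c1ccc(Cl)cc1)c1ccc(NS(C)(=O)=O)c(F)c1` gives 0.7 nM in this assay. Going by the values given here, the one measured step, a 3.5-fold lower number from compound 1 to compound 2 (0.54 log units; beyond the scatter), came from 3-chloro-4-fluorophenyl in place of 4-chlorophenyl.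

Compound 3 `Cc1cc(-c2nc(C(F)(F)F)ccc2CNC(=O)C(C)c2ccc(NS(C)(=O)=O)c(F)c2)ccc1F` differs from compound 2 by methyl in place of chloro on an aromatic carbon, on the same ring that the measured step altered. Among the compounds with values here, no measured step swaps chloro for methyl, so that step gives only weak guidance. With both groups of similar size, only a small change is expected, a 2.0-fold higher number from compound 2 to compound 3 (0.30 log units; within the scatter), and compound 3 is estimated at 0.4 nM in this assay, between 0.12 nM and 1.3 nM.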

Compound 3, inhibition constant: 0.4 nM
Beside the measured number, compound 3's estimate shows no gap at the digits printed; low and high end bracket the measured number.
By their numbers in this assay, from the lowest: compounds 2, 3 and 1 (each within the scatter of the next, the first and the last beyond it).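

Methyl in place of chloro, ortho to a fluoro group, gives a 2.0-fold higher number from compound 2 to compound 3 (0.30 log units; within the scatter), so in this assay this position takes either group with no difference that stands clear of the scatter. The 4-fluoro-3-methylphenyl in place of 4-chlorophenyl gives a 1.8-fold lower number from compound 1 to compound 3 (0.24 log units; within the scatter), so unlike the 3-chloro-4-fluorophenyl change, this replacement stays within the scatter. Nothing measured here gives a reason for these results.

On these data alone, whether methoxy, bromo or a nitrile at this position would read like chloro and methyl remains open.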